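Amide Exchange on a Thiophene Analogue: An Expected Outcome

The compounds below may be only part of what the source reports. "The series", "measured", "known", "first", "only" and "open" are said of these compounds alone.

Three compounds have been measured in an assay on membranes from CHO cells for displacement of a labelled ligand from adenosine receptor A1 (Homo sapiens), read by scintillation counting, with a stated time of 60 min, tested at 1 uM; on this read-out lower numbers stand for less inhibition and higher numbers for more inhibition at the one concentration tested (going by the name of the read-out):

compound 1, `CC1=C(C(=O)NC(C)C)C(c2ccco2)NC(=O)N1`, gives 3%
compound 2, `CCN(CC)C(=O)C1=C(C)NC(=O)NC1c1ccco1`, gives 11%
compound 3, `CC1=C(C(=O)NC(C)C)C(c2ccsc2)NC(=O)N1`, gives 8%

Compound 2 differs from compound 1 by diethylamino in place of isopropylamino on a carbonyl carbon, and in this assay this gave a number 8 percentage points higher from compound 1 to compound 2 (within the scatter). Compound 3 differs from compound 1 in its core by thiophen-3-yl in place of furan-2-yl on a saturated ring carbon, with a number 5 percentage points higher from compound 1 to compound 3 (within the scatter). All three numbers lie within the scatter of one another, so no order among them is claimed.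

Compound 4, `CCN(CC)C(=O)C1=C(C)NC(=O)NC1c1ccsc1`, has not been measured. It differs from compound 3 by diethylamino in place of isopropylamino on a carbonyl carbon, the same change as that from compound 1 to compound 2, made at the same place. The step is expected to resemble it: a number 6 percentage points higher from compound 3 to compound 4 (within the scatter), because a number 8 percentage points higher from compound 1 to compound 2 (within the scatter) was small. Compound 4 is therefore estimated at 14% in this assay, between 0% and 30%.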

Compound 4, a percentage reported as inhibition, at one concentration (the size of the read-out at that concentration, not a potency): 11%
Compound 4: middle estimate off by 3 percentage points, on the high side; low and high end bracket the measured number.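

In this assay, diethylamino in place of isopropylamino on a carbonyl carbon gave a number 3 percentage points higher from compound 3 to compound 4 (within the scatter), and this step agrees with the earlier one on the other core: the same change on two cores in this assay, a number 8 percentage points higher (within the scatter) from compound 1 to compound 2 and a number 3 percentage points higher (within the scatter) from compound 3 to compound 4, 5 percentage points apart, within the scatter of two such steps. Thiophen-3-yl in place of furan-2-yl on a saturated ring carbon gave no change at the digits printed from compound 2 to compound 4 (within the scatter), which likewise agrees with its earlier counterpart: the same change on two cores in this assay, a number 5 percentage points higher (within the scatter) from compound 1 to compound 3 and no change at the digits printed (within the scatter) from compound 2 to compound 4, 5 percentage points apart, within the scatter of two such steps. Among the compounds shown here, since every one of these steps lies within the scatter, the agreement shows only that neither change gave a readable step on either core, not that a real effect carries from one core to the other.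

The compounds shown leave open whether benzylamino or a longer alkylamino chain on the carbonyl carbon would give a step beyond the scatter. They leave the same question open for phenyl on the saturated ring carbon.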